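This account rests on a few compounds, and the source may have more. Where it says the series, first, only, none or still open, it means among the compounds named here.

Compound 2 `COc1cccc2[nH]c(C(=O)N[C@@H](CC3CC3)C(=O)N[C@@H](C[C@@H]3CCNC3=O)C(O)S(=O)(=O)O)cc12` sits at the edge of what an ADME assay on Vero C1008 cells (Chlorocebus sabaeus) for cytotoxicity, read by luminescence and CellTiter-Glo, with a stated time of 24 h (on this read-out lower numbers stand for higher toxicity in this test and higher numbers for lower toxicity in this test), can report: its value of > 200000 nM is a limit of the assay, not a number. Compound 1 `O=C(N[C@@H](CC1CC1)C(=O)N[C@@H](C[C@@H]1CCNC1=O)C(O)S(=O)(=O)O)OCc1cccc(F)c1` likewise gives > 200000 nM in this assay, again a limit. The step that the two limits leave unreadable from compound 1 to compound 2 stays unreadable because of the limit of > 200000 nM in this assay, at which 2 of the 2 values shown sit. Compound 3 `C[C@H](OC(=O)N[C@@H](CC1CC1)C(=O)N[C@@H](C[C@@H]1CCNC1=O)C(O)S(=O)(=O)O)c1ccccc1` differs from compound 2 by 1-phenylethoxy in place of 4-methoxy-1H-indol-2-yl on a carbonyl carbon. Going by the values given here, with every measured value resting at the limit, no measured step supplies a direction, so no step beyond the scatter is expected. Compound 3 is therefore expected to show 250000 nM in this assay, within 100000 nM to 600000 nM. This amounts to an expected step that the limit leaves unreadable from compound 2 to compound 3.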

Compound 3, half-maximal cytotoxic concentration: > 200000 nM
Compound 3: only a limit was reported; the forecaster's own chance of this, stated with the estimate: 85%; the middle value lies beyond the limit too.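

No new step can be read between compound 1, compound 2 and compound 3, because none of them gives a number: the limit of > 200000 nM in this assay, at which 3 of the 3 values shown sit.

The compounds shown leave open whether any group on this carbonyl carbon would give a readable number in this assay.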